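The source may hold more compounds than are shown below. What is called first, only, known or untested is meant among the compounds shown, and "the series" means these compounds.

Measured set in a functional assay on cells (Pituitary gland cell) for antagonist activity at Gonadotropin-releasing hormone receptor (Rattus norvegicus); a higher number here means a weaker inhibitor, a lower number a stronger inhibitor:
compound 1 `O=[N+]([O-])c1cc2c(OCCC3CCCCN3)c(-c3cccc(Cl)c3)c(O)nc2cc1Cl` gives 40 nM
compound 2 `O=[N+]([O-])c1cc2c(OCCC3CCCCN3)c(-c3ccccc3Cl)c(O)nc2cc1Cl` gives 360 nM
compound 3 `O=[N+]([O-])c1cc2c(OCCC3CCCCN3)c(-c3cccs3)c(O)nc2cc1Cl` gives 220 nM

Compound 3 stands second highest of the three numbers in this assay; its value and that of compound 2 lie within the scatter of each other, while compound 1 sits clearly below, the gap being a 5.5-fold higher number from compound 1 to compound 3 (0.74 log units; beyond the scatter). Compound 4 `O=[N+]([O-])c1cc2c(OCCC3CCCCN3)c(-c3cccc(F)c3)c(O)nc2cc1Cl` differs from compound 3 by 3-fluorophenyl in place of thiophen-2-yl on an aromatic carbon. Within the data shown here, the steps that bear on this are a 5.5-fold higher number from compound 1 to compound 3 (0.74 log units; beyond the scatter) and a 9.0-fold higher number from compound 1 to compound 2 (0.95 log units; beyond the scatter); both are modest and beyond the scatter, and both leave the 3-chlorophenyl of compound 1 with the lowest number. Since 3-fluorophenyl brings compound 4 closer to compound 1 than to compound 3, the move is expected to undo most of a 5.5-fold higher number from compound 1 to compound 3 (0.74 log units; beyond the scatter), giving an expected 3.7-fold lower number from compound 3 to compound 4 (0.56 log units; beyond the scatter). Compound 4 is therefore estimated at 60 nM, range 25 nM to 150 nM.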

Compound 4, half-maximal inhibitory concentration: 53 nM
For compound 4 the middle estimate is 1.1-fold (0.05 log units) above the measured one; low and high end bracket the measured number.
By their numbers in this assay, from the lowest: compounds 1 and 4 (each within the scatter of the next); then compounds 3 and 2 (each within the scatter of the next).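

With the 3-chlorophenyl of compound 1 exchanged for the 3-fluorophenyl of compound 4, the number in this assay does not separate from that of compound 1 (a 1.3-fold higher number from compound 1 to compound 4 (0.12 log units; within the scatter)), so fluoro can stand in place of chloro here. Compound 4 also lies clearly below the thiophen-2-yl compound (a 4.2-fold lower number from compound 3 to compound 4 (0.62 log units; beyond the scatter)) and the 2-chlorophenyl compound (a 6.8-fold lower number from compound 2 to compound 4 (0.83 log units; beyond the scatter)), so both 3-halophenyl groups now share the low end of this small set. No measurement given here explains these differences. Open is whether a halogen is needed at all: unsubstituted phenyl, 3-methoxyphenyl and 3-(trifluoromethyl)phenyl are not among the compounds shown.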